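Methyl for methoxy across two pairs of one series

The source may hold more compounds than are shown below. What is called first, only, known or untested is meant among the compounds shown, and "the series" means these compounds.

Compound 1 `C#CCn1c(=O)c(C=O)cc2cc(OC)ccc21` was run in a functional assay on A549 cells (Homo sapiens) for cytotoxicity, read by MTT assay, with a stated time of 24 h; on this read-out lower numbers stand for stronger inhibition and higher numbers for weaker inhibition; compound 1 gives only a limit there, > 100000 nM. Compound 2 `C#CCn1c(=O)c(C=O)cc2cc(C)ccc21` also gives only a limit in this assay, > 100000 nM. The change between these two is methyl in place of methoxy on an aromatic carbon, and the step that the two limits leave unreadable from compound 1 to compound 2 cannot be read because of the limit of > 100000 nM in this assay, at which 2 of the 3 values shown sit. For the measured compounds named here, compound 3 `C#CCn1c(=O)c(/C=C/C(=O)/C=C(O)/C=C/c2ccc(O)c(OC)c2)cc2cc(OC)ccc21` is the only member with a number: in this assay compound 3 gives 20600 nM. How the core of compound 3 differs from the core of compound 1 is not broken down here. Compound 4 `C#CCn1c(=O)c(/C=C/C(=O)/C=C(O)/C=C/c2ccc(O)c(OC)c2)cc2cc(C)ccc21` is not yet measured; it differs from compound 3 by methyl in place of methoxy on an aromatic carbon, the same change as from compound 1 to compound 2, made at a place described in the same words. The size of that change on the one measured pair is not readable, so nothing shown fixes its direction. Relative to compound 3, the value of compound 4 is expected to move by a 1.2-fold higher number from compound 3 to compound 4 (0.08 log units; within the scatter), taken as small in the absence of a readable step. In this assay compound 4 is thus estimated at 25000 nM, with a likely range from 8000 nM to 70000 nM.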

Compound 4, half-maximal inhibitory concentration: 23900 nM
Estimate against measurement, compound 4: 1.0-fold (0.02 log units) above; the range from low to high includes it.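

In this assay, methyl in place of methoxy on an aromatic carbon gives a 1.2-fold higher number from compound 3 to compound 4 (0.06 log units; within the scatter), so on the core of compound 3 this change shows no effect that can be told from scatter. The same change on the core of compound 1 cannot be read, and the reason lies in the limit shared by both members of that pair: the limit of > 100000 nM in this assay, at which 2 of the 4 values shown sit. Agreement between the two cores is therefore not shown, and a single readable pair gives no rule for carrying the change from one core to another.

The compounds shown hold only methoxy or methyl at this aromatic carbon, so the outcome with an amine, a carboxylic acid or a longer chain such as ethoxy there remains open. Also open, going by these compounds, is whether any such group on the core of compound 3 would give a step beyond the scatter in this assay.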